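This account rests on a few compounds, and the source may have more. Where it says the series, first, only, none or still open, it means among the compounds named here.

Measured compounds:
compound 1, `Clc1ccc(-c2csc(N/N=C/c3cccs3)n2)cc1`, in a functional assay, read by spectrophotometry, with a stated time of 15 min, tested at 80 ug/mL (on this read-out higher numbers stand for a stronger effect at the one concentration tested and lower numbers for a weaker effect), compound 1 gives 86%
compound 2, `Fc1ccc(-c2csc(N/N=C/c3cccs3)n2)cc1`, in this assay compound 2 gives 91.9%

On these two numbers compound 2 stands at the top, with compound 1 the nearest, but the step of a number 5.9 percentage points higher from compound 1 to compound 2 (within the scatter) lies within the scatter, so the two cannot be separated. Compound 3, `Cc1ccc(-c2csc(N/N=C/c3cccs3)n2)cc1`, is the next member; it differs from compound 2 by methyl in place of fluoro on an aromatic carbon. For the measured compounds named here, only one measured step concerns an exchange at this aromatic carbon, namely a number 5.9 percentage points higher from compound 1 to compound 2 (within the scatter), and it was within the scatter. Going by the values given here, a methyl at this place has no precedent, so nothing measured supports a step beyond the scatter in either direction in this assay. Compound 3 is therefore expected to sit close to compound 2, the expected step being a number 4.9 percentage points lower from compound 2 to compound 3 (within the scatter). The estimate for compound 3 is 87%, with a range from 74% to 96%.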

Compound 3, a percentage reported as inhibition, at one concentration (the size of the read-out at that concentration, not a potency): 88.4%
For compound 3 the middle estimate is 1.4 percentage points below the measured one, and the stated range covers the measured number.
By their numbers in this assay, from the lowest: compounds 1, 3 and 2 (each within the scatter of the next).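

In this assay, the exchange at this aromatic carbon is no longer only one halogen for another: with methyl, a carbon group enters, and the step is a number 3.5 percentage points lower from compound 2 to compound 3 (within the scatter). Against the chloro compound the picture is the same, with a number 2.4 percentage points higher from compound 1 to compound 3 (within the scatter), so all three groups at this place, para to a large group, fall within the scatter of one another and none can be ranked. Nothing available speaks to why these steps are small.

Going by these compounds, whether this flat picture holds for an amine, a carboxylic acid or a longer chain at this place remains open. Also open, on these data alone, is what a change elsewhere on the shared core would do, and since the read-out comes from one concentration, it tells only of a stronger or weaker effect at that concentration.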